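This account rests on a few compounds, and the source may have more. Where it says the series, first, only, none or still open, it means among the compounds named here.

Values in a functional assay on SH-SY5Y cells (Homo sapiens) for cytotoxicity, read by MTT assay, with a stated time of 72 h; on this read-out lower numbers stand for stronger inhibition and higher numbers for weaker inhibition:

compound 1 `CN(C)CCCCn1c2c(c3ccccc31)C(=O)c1c[n+]([O-])c3ccccc3c1C2=O` gives 250 nM
compound 2 `O=C1c2c[n+]([O-])c3ccccc3c2C(=O)c2c1c1ccccc1n2CCN1CCCC1` gives 520 nM
compound 3 `CCCN1CCN(CCCCn2c3c(c4ccccc42)C(=O)c2c[n+]([O-])c4ccccc4c2C3=O)CC1` gives 3970 nM

Compound 3 stands highest of the three numbers; its nearest neighbour is compound 2 (a 7.6-fold higher number from compound 2 to compound 3 (0.88 log units; beyond the scatter)) and the furthest is compound 1 (a 16-fold higher number from compound 1 to compound 3 (1.20 log units; beyond the scatter)).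

Compound 4 `O=C1c2c[n+]([O-])c3ccccc3c2C(=O)c2c1c1ccccc1n2CCCCn1ccnc1` differs from compound 3 as follows: 1H-imidazol-1-yl in place of 4-propylpiperazin-1-yl on a saturated chain carbon, four bonds along the chain from an aromatic nitrogen.

The step that bears most directly on this change is the one at the same place on the chain, from compound 1 to compound 3 (a 16-fold higher number from compound 1 to compound 3 (1.20 log units; beyond the scatter)), where the 4-propylpiperazin-1-yl group arrived and the number rose sharply. Its removal in favour of 1H-imidazol-1-yl, a smaller five-membered aromatic ring, is therefore expected to move the number back down, though 1H-imidazol-1-yl is not dimethylamino and a full return to the level of compound 1 is not assumed. The step from compound 1 to compound 2 (a 2.1-fold higher number from compound 1 to compound 2 (0.32 log units; beyond the scatter)) concerns a different place and gives only a loose sense of how much the chain-end group matters.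

Compound 4 is expected to give 1200 nM, within 400 nM to 3500 nM, a step of a 3.3-fold lower number from compound 3 to compound 4 (0.52 log units; beyond the scatter).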

Compound 4, half-maximal inhibitory concentration: 130 nM
Beside the measured number, compound 4's estimate is 9.2-fold (0.97 log units) above it, and the stated range ends above it.
By their numbers in this assay, from the lowest: compounds 4 and 1 (each within the scatter of the next); then compound 2; then compound 3.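

In this assay, 1H-imidazol-1-yl in place of 4-propylpiperazin-1-yl gives a 31-fold lower number from compound 3 to compound 4 (1.48 log units; beyond the scatter) at this place on the chain, so the high number of compound 3 does not extend to every ring here. Set against dimethylamino at the same place, the change gives a 1.9-fold lower number from compound 1 to compound 4 (0.28 log units; within the scatter), so an aromatic five-membered ring and the dimethylamino group cannot be told apart in this assay. The comparison with the pyrrolidin-1-yl of compound 2 gives a 4.0-fold lower number from compound 2 to compound 4 (0.60 log units; beyond the scatter) and reads as 2-(1H-imidazol-1-yl)ethyl in place of pyrrolidin-1-yl, so it involves the chain as well as the ring.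

No supporting measurement is available to explain any of these steps.
Going by these compounds, whether a morpholin-4-yl group or a 1H-1,2,4-triazol-1-yl group at this place would stay near compound 4, and whether 1H-imidazol-1-yl on a two-carbon ethyl chain would keep its value, remains open.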